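A few compounds are considered here, and "the series" means these few. Any claim that something is new, unique, unknown or untested is made for them only; others in the source may bear on it.

Measured so far:
Compound 1, `COC(=O)c1ccc(OCCCCOc2ccc(C(=O)CC3CCCC3)c(O)c2C)cc1`: 12.2%
Compound 2, `Cc1c(OCCCCOc2ccc(C(=O)O)cc2F)ccc(C(=O)CC(C)C)c1O`: 85%
Compound 3, `Cc1c(OCCCCOc2ccc(C(=O)O)cc2)ccc(C(=O)CC(C)C)c1O`: 88%

In an assay on HEK293 cells for positive allosteric modulation of metabotropic glutamate receptor 2 (Rattus norvegicus), read by thallium flux, with a stated time of 2.5 min (a higher number here means a larger maximal response, a lower number a smaller maximal response), compound 3 stands at the highest of the three numbers, though compound 2 sits within the scatter of it, and compound 1 lies far below it. For the measured compounds named here, the only measured step, a number 3 percentage points higher from compound 2 to compound 3 (within the scatter), concerns a different part of the molecule and says little about the change now in question, which is methyl in place of hydrogen on an oxygen next to a carbonyl group, giving compound 4, `COC(=O)c1ccc(OCCCCOc2ccc(C(=O)CC(C)C)c(O)c2C)cc1`. Going by the values given here, no measured pair isolates this change; what the numbers do show is that compound 1, which also carries a 4-(methoxycarbonyl)phenyl group, gives 12.2%. Compound 4 is therefore expected to fall, by about a number 58 percentage points lower from compound 3 to compound 4 (beyond the scatter), to an estimated 30%, within the range 8% to 75%.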

Compound 4, largest response reached (reported as percent of maximum), in percent of the reference or control that the assay uses: 16.4%
The estimate for compound 4 lay 13.6 percentage points above the measured number; the measured number falls inside the stated range.
By their numbers in this assay, from the lowest: compounds 1 and 4 (each within the scatter of the next); then compounds 2 and 3 (each within the scatter of the next).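

In this assay, turning the carboxy group into methoxycarbonyl removes most of the response (a number 71.6 percentage points lower from compound 3 to compound 4 (beyond the scatter)), and the step from the 4-carboxy-2-fluorophenyl compound is of similar size (a number 68.6 percentage points lower from compound 2 to compound 4 (beyond the scatter)). Among the two methoxycarbonyl compounds, isopropyl and cyclopentyl stand level (a number 4.2 percentage points higher from compound 1 to compound 4 (within the scatter)), so the low number of compound 1 need not be tied to its cyclopentyl group. Nothing measured here gives a reason for this loss.

On these data alone, an amide or a tetrazole in place of the carboxy group remains open, as does cyclopentyl paired with the free carboxylic acid.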